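Swapping cyclobutyl for isopropoxy on a benzoylguanidine

The compounds below may be only part of what the source reports. "The series", "measured", "known", "first", "only" and "open" are said of these compounds alone.

Measured so far:
compound 1 `CCc1cc(Br)c(S(C)(=O)=O)cc1C(=O)N=C(N)N` gives 41 nM
compound 2 `CS(=O)(=O)c1cc(C(=O)N=C(N)N)c(Cl)cc1Cl` gives 140 nM
compound 3 `Cc1cc(C2CCC2)c(S(C)(=O)=O)cc1C(=O)N=C(N)N` gives 8.2 nM

These three compounds were tested in a functional assay for inhibition of sodium/hydrogen exchanger (Oryctolagus cuniculus); on this read-out higher numbers stand for weaker inhibition and lower numbers for stronger inhibition. Among them compound 3 stands lowest; its gap to compound 1 is beyond the scatter, and its gap to compound 2 is wider still, so compound 3 is the strongest inhibitor of the three on this read-out. No pair of these compounds differs in a single place, so no single change among them can be sized.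

Compound 4 `Cc1cc(OC(C)C)c(S(C)(=O)=O)cc1C(=O)N=C(N)N` has not yet been measured. It is derived from compound 3 by a single change: isopropoxy in place of cyclobutyl on an aromatic carbon. The group that leaves and the group that enters are of equal size in heavy atoms, and the other substituents of the shared core are kept.

Going by the values given here, with no measured step of the same kind to lean on, the expectation rests on compound 3 alone, whose value 8.2 nM is the anchor. In this assay compound 4 is expected to land near compound 3, with a step of a 1.8-fold higher number from compound 3 to compound 4 (0.26 log units; within the scatter) that likely stays within the scatter. The estimate for compound 4 is 15 nM, with a range from 4 nM to 60 nM.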

Compound 4, half-maximal inhibitory concentration: 19 nM
Compound 4: the middle estimate sits 1.3-fold (0.10 log units) below what was measured; low and high end bracket the measured number.
By their numbers in this assay, from the lowest: compound 3; then compound 4; then compound 1; then compound 2.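

Going by these compounds alone, the first single change that can be sized in this assay lies on the aromatic carbon ortho to a methylsulfonyl group, where isopropoxy in place of cyclobutyl gives a 2.3-fold higher number from compound 3 to compound 4 (0.36 log units; beyond the scatter) as a modest step. The position therefore accepts an open isopropoxy with one hydrogen-bond acceptor in place of a carbon-only four-membered ring of equal heavy-atom count, and compound 4 still reads 19 nM in this series. Nothing available explains the step.

The compounds shown leave open whether the step follows from the entering oxygen or from the loss of the ring, which a cyclobutoxy or an isobutyl group at this carbon would separate. Going by these compounds, how an amine or a longer chain such as butoxy would read here also remains open.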